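Moving the chlorine on the pendant aryl of compound 1

The source may hold more compounds than are shown below. What is called first, only, known or untested is meant among the compounds shown, and "the series" means these compounds.

Compound 1 `O=S(=O)(c1cc(F)cc(F)c1)c1cnc2c(F)cccc2c1-c1cccc(Cl)c1` in an ADME assay on microsomes from liver (Homo sapiens) for metabolic stability, tested at 2.5 uM (a lower number here means slower removal, a higher number faster removal of the compound), gives 0.64 mL/min, the second highest of the three numbers shown; nearest stands compound 3 `O=S(=O)(c1cccc(F)c1)c1cnc2c(F)cccc2c1-c1cccc(Cl)c1` at 0.56 mL/min, and furthest compound 2 `O=S(=O)(c1cc(Cl)cc(Cl)c1)c1cnc2c(F)cccc2c1-c1cccc(Cl)c1` at 1.2 mL/min. The change to compound 4 `O=S(=O)(c1cc(F)cc(F)c1)c1cnc2c(F)cccc2c1-c1ccc(Cl)cc1` is 4-chlorophenyl in place of 3-chlorophenyl on an aromatic carbon. Within the data shown here, no measured step alters this part of the shared core; the known steps all alter the aryl on the sulfonyl sulfur: a 1.9-fold higher number from compound 1 to compound 2 (0.27 log units; within the scatter), a 1.1-fold lower number from compound 1 to compound 3 (0.06 log units; within the scatter) and a 2.1-fold lower number from compound 2 to compound 3 (0.33 log units; beyond the scatter). Across these the series barely moves. Among the measured compounds shown here, with no direct precedent, no step beyond the scatter is expected for compound 4: a 1.1-fold higher number from compound 1 to compound 4 (0.04 log units; within the scatter). Compound 4 is therefore estimated at 0.7 mL/min, with a range from 0.35 mL/min to 1.4 mL/min.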

Compound 4, intrinsic clearance in a liver preparation (reported as CLH), per the amount of preparation that the assay uses: 0.73 mL/min
Beside the measured number, compound 4's estimate is 1.0-fold (0.02 log units) below it; measured number inside the range.
By their numbers in this assay, from the lowest: compounds 3, 1, 4 and 2 (each within the scatter of the next, the first and the last beyond it).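

Among these compounds, the only measured step on this aryl, rather than on the aryl on the sulfonyl sulfur, is 4-chlorophenyl in place of 3-chlorophenyl: a 1.1-fold higher number from compound 1 to compound 4 (0.06 log units; within the scatter) in this assay. Moving the chlorine between these two positions therefore leaves the number within the scatter for this one pair. Nothing available explains the result.

Open is how far this tolerance extends, since every compound shown carries a chlorine on this ring. An amine or a carboxylic acid here could behave differently, and the same chlorine move remains unread alongside 3,5-dichlorophenyl on the sulfonyl sulfur.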